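Mirror-image cyclopropane amides on a shared bicyclic core

A few compounds are considered here, and "the series" means these few. Any claim that something is new, unique, unknown or untested is made for them only; others in the source may bear on it.

Three compounds share one core, an amide on a bridged bicyclic amine, and differ only in the group on the carbonyl carbon. In an assay on SH-EP1 cells for agonist activity at Neuronal acetylcholine receptor; alpha4/beta2 (Homo sapiens), read by FLIPR and calcium flux (a lower number here means that less compound is needed, a higher number that more compound is needed for the effect), compound 1 `CC(=O)N1CC2CC(C1)N2` gives 9700 nM, compound 2 `CCCC(=O)N1CC2CC(C1)N2` gives 850 nM, and compound 3 `C[C@@H]1C[C@@H]1C(=O)N1CC2CC(C1)N2` gives 3800 nM. Compound 3 has the second highest number of the three: the step of a 2.6-fold lower number from compound 1 to compound 3 (0.41 log units; beyond the scatter) and the step of a 4.5-fold higher number from compound 2 to compound 3 (0.65 log units; beyond the scatter) place it between the other two, and both steps lie beyond the scatter.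

Compound 4 `C[C@H]1C[C@H]1C(=O)N1CC2CC(C1)N2` is the mirror image of compound 3: the two compounds have the same atoms and bonds; at least one stereo element is drawn with a configuration in one of them and without one in the other: 2 of 4 stereo elements differ; a stereocentre at a saturated ring carbon is drawn R in compound 3 and S in compound 4; a stereocentre at a saturated ring carbon is drawn S in compound 3 and R in compound 4. Among the measured compounds shown here, none of the measured steps concerns a change of drawn stereochemistry; they all exchange groups on the carbonyl carbon, so no measured step bears directly on this one. Mirror images can give equal or quite different numbers in this assay, and the shown compounds do not tell which. Compound 4 is therefore expected to give about 4500 nM, between 1000 nM and 20000 nM, a step of a 1.2-fold higher number from compound 3 to compound 4 (0.07 log units; within the scatter) that is uncertain in direction and is as likely to be none beyond the scatter as to be a real one.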

Compound 4, half-maximal effective concentration: 5800 nM
Compound 4: the middle estimate sits 1.3-fold (0.11 log units) below what was measured, within the range that was stated.
By their numbers in this assay, from the lowest: compound 2; then compounds 3, 4 and 1 (each within the scatter of the next, the first and the last beyond it).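

In this assay, reversing the drawn configuration of the 2-methylcyclopropyl group gives a 1.5-fold higher number from compound 3 to compound 4 (0.18 log units; within the scatter), so the two mirror-image forms cannot be told apart here. Compound 4 also stays clearly behind the propyl compound, with a 6.8-fold higher number from compound 2 to compound 4 (0.83 log units; beyond the scatter), while a 1.7-fold lower number from compound 1 to compound 4 (0.22 log units; within the scatter) does not separate it from the methyl compound, unlike compound 3, whose step from compound 1 lies beyond the scatter. This reading of the pair carries one caveat from the way the structures are drawn: the fact that one of compounds 3 and 4 is drawn with a defined configuration and the other without, at the place where they differ.

The compounds shown leave open how a plain cyclopropyl group without the methyl would compare with the 2-methylcyclopropyl pair. They also leave open whether a longer chain, such as butyl or pentyl, on the carbonyl carbon would give a lower number than propyl.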